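Amine replacement on the shared core: lipophilicity notes

A few compounds are considered here, and "the series" means these few. Any claim that something is new, unique, unknown or untested is made for them only; others in the source may bear on it.

Measured so far in a physicochemical assay for lipophilicity; a lower number here means a more polar compound, a higher number a more lipophilic compound:
compound 1 `CC(C)Sc1nnc(-c2c(CN3CCC(N4CCCC4)CC3)c3ccccc3n2C)n1-c1ccccc1`: 5.16
compound 2 `CC(C)Sc1nnc(-c2c(CN3CCCCC3C)c3ccccc3n2C)n1-c1ccccc1`: 5.95

Compound 1 stands lowest of the two numbers in this assay; its nearest neighbour is compound 2, reached by a number 0.79 log units higher from compound 1 to compound 2 (beyond the scatter). The next compound, compound 3 `COCCNCc1c(-c2nnc(SC(C)C)n2-c2ccccc2)n(C)c2ccccc12`, is not yet measured. It differs from compound 1 in one place: (2-methoxyethyl)amino in place of 4-(pyrrolidin-1-yl)piperidin-1-yl on a saturated chain carbon bound to an aromatic carbon. Going by the values given here, only one measured step bears on this change, and it does so loosely: the step from compound 1 to compound 2 also replaces the same leaving group and raised this assay by a modest amount, but the entering group in compound 3 is not the one in compound 2, as the counted difference shows. Among the compounds with values here, with no closer precedent, the expectation for compound 3 is a step of a number 0.16 log units lower from compound 1 to compound 3 (within the scatter), that is no clear movement beyond the scatter, with a wide range. Compound 3 is therefore estimated at 5, between 4.4 and 5.6.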

Compound 3, partition coefficient: 4.36
Compound 3: middle estimate off by 0.64 log units, on the high side; measured number below the stated range.
By their numbers in this assay, from the lowest: compound 3; then compound 1; then compound 2.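

In this assay, the saturated chain carbon bound to an aromatic carbon now shows movement in both directions from compound 1: the change to (2-methoxyethyl)amino gives a number 0.80 log units lower from compound 1 to compound 3 (beyond the scatter), whereas the earlier change to 2-methylpiperidin-1-yl gave a number 0.79 log units higher from compound 1 to compound 2 (beyond the scatter). The two amines at the extremes are far apart, with a number 1.59 log units lower from compound 2 to compound 3 (beyond the scatter), so the choice of amine here alone spans a wide stretch of this assay. The entering (2-methoxyethyl)amino group has fewer heavy atoms than 4-(pyrrolidin-1-yl)piperidin-1-yl, no ring and one hydrogen-bond donor, but nothing measured here explains the step or assigns it to any of these differences.

As far as these compounds go, how much of the step goes with the loss of the ring and how much with the hydrogen-bond donor remains open. A morpholin-4-yl group or the tertiary N-methyl amine of the same chain at this place would help to separate the two.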